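Aryloxy swap in a coumarin-pyrazole series at the assay limit

The source may report more compounds than this note shows. Statements on the series, on what has been measured and on what is new or still open speak of the compounds shown alone.

compound 1 `Cc1nn(C)c(Oc2ccc(Br)cc2)c1/C=N\CCCCCOc1cc2oc(=O)cc(C)c2cc1Cl`: "not determined" (no result reported)
compound 2 `Cc1nn(C)c(Oc2ccc(F)cc2F)c1/C=N\CCCCCCOc1cc2oc(=O)cc(C)c2cc1Cl`: > 25000 nM

In a functional assay on SMMC-7721 cells (Homo sapiens) for antiproliferative activity, read by MTT assay, with a stated time of 72 h (on this read-out higher numbers stand for weaker inhibition and lower numbers for stronger inhibition), compound 2 gives > 25000 nM, which is a limit of the assay and not a number. Compound 1 has no result in this assay. Among the compounds with values here, compound 2 therefore sits at the limit of > 25000 nM in this assay, at which 1 of the 2 values shown sits, the only entry with any value, and the one further entry carries no number. Compound 3 `Cc1nn(C)c(Oc2ccc(OC(F)(F)F)cc2)c1/C=N\CCCCCCOc1cc2oc(=O)cc(C)c2cc1Cl` carries 4-(trifluoromethoxy)phenyl in place of 2,4-difluorophenyl on an oxygen on an aromatic ring. Within the data shown here, with no step between measured compounds, no size or direction can rest on measured data. Compound 3 is expected to remain near the limit, at 30000 nM (5000 nM to 100000 nM). The step that the limit leaves unreadable from compound 2 to compound 3 is expected to lie within the scatter.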

Compound 3, half-maximal inhibitory concentration: 6350 nM
For compound 3 the middle estimate is 4.7-fold (0.67 log units) above the measured one; low and high end bracket the measured number.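

In this assay, the aryl group on this oxygen proves able to move the read-out: 4-(trifluoromethoxy)phenyl in place of 2,4-difluorophenyl gives an at least 3.9-fold lower number from compound 2 to compound 3 (0.59 log units; beyond the scatter). Compound 3 thereby supplies the first single number in this set, so the true size of the step stays unknown only on the side of compound 2, which holds a limit and not a number: the limit of > 25000 nM in this assay, at which 1 of the 3 values shown sits.

On these data alone, both the ring pattern and the substituent change in this one swap, so which of them carries the step stays open. As far as these compounds go, how an unsubstituted phenyl or a methoxyphenyl would read on this oxygen is also open.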